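A few compounds are considered here, and "the series" means these few. Any claim that something is new, unique, unknown or untested is made for them only; others in the source may bear on it.

Among the compounds with values here, in an ADME assay on Huh-7 cells (Homo sapiens) for cytotoxicity (a higher number here means that more compound is tolerated, a lower number that less compound is tolerated), compound 2 `O=C(NC(=S)N1CCc2c(OCCCCCOc3ccc(Cl)cc3)cccc21)c1ccco1` gives 4620 nM, the only actual number so far. Compound 1 `CC(C)(C)c1ccc(C(=O)NC(=S)N2CCc3c(OCCCCCOc4ccc(Cl)cc4)cccc32)cc1` gives only a limit of this assay, > 50000 nM. Within the data shown here, the one measured step, an at least 10-fold lower number from compound 1 to compound 2 (1.03 log units; beyond the scatter), concerns a different change at the same carbonyl carbon. Compound 3 `O=C(NC(=S)N1CCc2c(OCCCCCOc3ccc(Cl)cc3)cccc21)c1cccs1` differs from compound 2 by thiophen-2-yl in place of furan-2-yl on a carbonyl carbon. Among the measured compounds shown here, no measured step covers this swap of one five-membered aromatic ring for another, so no step beyond the scatter is expected, and the estimated change is a 1.2-fold lower number from compound 2 to compound 3 (0.06 log units; within the scatter). Compound 3 is therefore expected to give 4000 nM, between 1500 nM and 12000 nM.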

Compound 3, half-maximal cytotoxic concentration: 10700 nM
For compound 3 the middle estimate is 2.7-fold (0.43 log units) below the measured one, within the range that was stated.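

Swapping one five-membered aromatic ring for another at this carbonyl carbon is not a neutral change in this assay: the result is a 2.3-fold higher number from compound 2 to compound 3 (0.36 log units; beyond the scatter). The two rings have the same number of heavy atoms and differ only in oxygen versus sulfur, so similar-looking rings need not behave alike here. Thiophen-2-yl still stays well short of 4-(tert-butyl)phenyl, with an at least 4.6-fold lower number from compound 1 to compound 3 (0.66 log units; beyond the scatter), but that step rests on a limit, so its full size cannot be read: the limit of > 50000 nM in this assay, at which 1 of the 3 values shown sits.

On these data alone, it remains open whether an unsubstituted phenyl or a small methyl group at this carbonyl carbon would fall nearer the five-membered rings or nearer 4-(tert-butyl)phenyl. As far as these compounds go, it is also open whether furan-2-yl and thiophen-2-yl would keep this order with a shorter chain on the shared core.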